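The compounds below may be only part of what the source reports. "The series", "measured", "known", "first", "only" and "open" are said of these compounds alone.

Compound 1 `COc1cccc(Nc2n[nH]c(-c3cccnc3Nc3cc(OC)cc(OC)c3)n2)c1` gives 72% in a functional assay on A-431 cells (Homo sapiens), tested at 0.1 uM; on this read-out lower numbers stand for less inhibition and higher numbers for more inhibition at the one concentration tested (going by the name of the read-out). Compound 2 `COc1ccc(Nc2n[nH]c(-c3cccnc3Nc3cc(OC)cc(OC)c3)n2)cc1` gives 68% in this assay. Compound 3 `COc1cc(Nc2ncccc2-c2n[nH]c(Nc3ccccc3)n2)cc(OC)c1` gives 22% in this assay.

Among these three numbers compound 2 and compound 1 lie within the scatter of each other, the only step between them being a number 4 percentage points lower from compound 1 to compound 2 (within the scatter). Compound 3, which carries a plain phenyl on the amine, gives 22%, whereas compound 2 gives 68%; this gap is well beyond the scatter, and compound 3 lies far lower than both of the others, though no single-step comparison between those two is available.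

Compound 4 `COc1cc(Nc2ncccc2-c2nc(Nc3ccc(OC)cc3OC)n[nH]2)cc(OC)c1` differs from compound 2 only in one place: methoxy in place of hydrogen on an aromatic carbon. Within the data shown here, the one measured step, a number 4 percentage points lower from compound 1 to compound 2 (within the scatter), shows that moving a single methoxy around the phenyl changes nothing beyond the scatter. Among the measured compounds shown here, no measured pair tells what adding a second methoxy on that ring does, so the direction of the step cannot be read from the data. The expectation for compound 4 in this assay is therefore a step of about a number 5 percentage points lower from compound 2 to compound 4 (within the scatter), which is within the scatter. Compound 4 is estimated at 63%, with a range from 35% to 85%.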

Compound 4, a percentage reported as inhibition, at one concentration (the size of the read-out at that concentration, not a potency): 17%
The estimate for compound 4 lay 46 percentage points above the measured number; measured number below the stated range.
By their numbers in this assay, from the lowest: compounds 4 and 3 (each within the scatter of the next); then compounds 2 and 1 (each within the scatter of the next).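

In this assay, methoxy in place of hydrogen on the aromatic carbon ortho to a large group, which turns 4-methoxyphenyl into 2,4-dimethoxyphenyl, gives a number 51 percentage points lower from compound 2 to compound 4 (beyond the scatter), and the change from 3-methoxyphenyl to 2,4-dimethoxyphenyl gives a number 55 percentage points lower from compound 1 to compound 4 (beyond the scatter). The earlier step, a number 4 percentage points lower from compound 1 to compound 2 (within the scatter), had shown only that the single methoxy could sit in either of two places on this ring without a change beyond the scatter; the new steps show that this ring is not indifferent to substitution, and that one added methoxy at this position is enough for a large loss of inhibition at the one concentration tested. Nothing available here explains that loss.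

The compounds shown leave open whether the loss belongs to methoxy itself or would also follow from a smaller or different group at this position, such as a fluorine atom, a methyl or a hydroxyl. They also leave open whether a 2-methoxyphenyl on the amine, without the second methoxy, would behave like 2,4-dimethoxyphenyl or like the two singly substituted rings.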